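The source may report more compounds than this note shows. Statements on the series, on what has been measured and on what is new or still open speak of the compounds shown alone.

Compound 3 `COC(=O)c1c(Nc2ccc(OC)cc2)sc(C(=O)c2ccc(OC)cc2)c1C` stands lowest of the two numbers in a functional assay, with a stated time of 150 min, tested at 15 ug/mL (a higher number here means a stronger effect of the compound at the concentration tested, a lower number a weaker effect), where compound 3 gives 7.8%; the nearest is compound 1 `COC(=O)c1c(Nc2ccccc2)sc(C(=O)c2ccc(OC)cc2)c1C`, which gives 28.6%, while compound 2 `COC(=O)c1c(Nc2ccc(C)cc2)sc(C(=O)c2ccc(OC)cc2)c1C` is reported as "not active" (no number reported) without a number. Compound 4 `COC(=O)c1c(Nc2ccc(F)cc2)sc(C(=O)c2ccc(OC)cc2)c1C` differs from compound 3 by fluoro in place of methoxy on an aromatic carbon. Going by the values given here, no measured step exchanges these two groups; the only step at this aromatic carbon, a number 20.8 percentage points lower from compound 1 to compound 3 (beyond the scatter), sets methoxy against hydrogen, and compound 2 with methyl in that place yields no number at all. The step of a number 4.2 percentage points higher from compound 3 to compound 4 (within the scatter) is therefore expected to be small, if anything upward, and likely within the scatter. Compound 4 is estimated at 12%, within 0% to 30%, with a real chance that this assay reports no number.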

Compound 4, a percentage reported as activity, at one concentration (the size of the read-out at that concentration, not a potency): 15.2%
The estimate for compound 4 lay 3.2 percentage points below the measured number; low and high end bracket the measured number.
By their numbers in this assay, from the lowest: compounds 3 and 4 (each within the scatter of the next); then compound 1.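

In this assay, the direct exchange of the two groups gives a number 7.4 percentage points higher from compound 3 to compound 4 (within the scatter) and so does not separate fluoro from methoxy. Fluoro in place of hydrogen gives a number 13.4 percentage points lower from compound 1 to compound 4 (beyond the scatter) and is thus the second group, after methoxy, whose number falls beyond the scatter from that of compound 1, though the modest steps rest on one concentration. No available evidence bears on the reason for this.

Going by these compounds, whether an amine or a carboxylic acid at this carbon would match compound 1 remains open. The read-outs show the size of the effect at one concentration only.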